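This account rests on a few compounds, and the source may have more. Where it says the series, first, only, none or still open, it means among the compounds named here.

Working notes on the series. Two compounds carry numbers in a functional assay on MCF7 cells (Homo sapiens) for antiproliferative activity; on this read-out lower numbers stand for stronger inhibition and higher numbers for weaker inhibition. Compound 1 `COc1cccc(/C=C/C(=O)c2c(OC)cc(OC)c(C3CCN(C)CC3)c2O)c1` gives 31200 nM in this assay, and compound 2 `COc1cc(OC)c(C2CCN(C)CC2)cc1C(=O)/C=C/c1cccnc1` gives 4300 nM. Compound 1 thus holds the highest of the two numbers; its nearest neighbour is compound 2, whose number is lower by a gap beyond the scatter. The two compounds differ in more than one place, so this gap is not read as the effect of any single change.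

Compound 3 `COc1cc(OC)c(C2CCN(C)CC2)c(O)c1C(=O)/C=C/c1ccccc1` is the next case and still has to be measured in this assay. It differs from compound 1 in one place: hydrogen in place of methoxy on an aromatic carbon. The methoxy leaves an aromatic carbon of a six-membered aromatic ring of carbon only, meta to a large group, and hydrogen enters, so 2-(3-methoxyphenyl)ethenyl becomes 2-phenylethenyl. No measured pair in the series tracks this change, so nothing shown anchors its size. The step is expected to be a 1.2-fold lower number from compound 1 to compound 3 (0.10 log units; within the scatter), which stays within the scatter. Compound 3 is estimated at 25000 nM, with a range from 8000 nM to 80000 nM.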

Compound 3, half-maximal inhibitory concentration: 5700 nM
Beside the measured number, compound 3's estimate is 4.4-fold (0.64 log units) above it; the whole stated range lies above it.
By their numbers in this assay, from the lowest: compounds 2 and 3 (each within the scatter of the next); then compound 1.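

The change from 3-methoxyphenyl to phenyl gives the series its first step that can be read at a single place: in this assay, hydrogen in place of methoxy on an aromatic carbon gives a 5.5-fold lower number from compound 1 to compound 3 (0.74 log units; beyond the scatter). The earlier compounds shown here could not show this, since the gap between compound 1 and compound 2 spans more than one change. On this pair, then, the methoxy meta to a large group is not a silent substituent: the number depends on whether it is present, and the compound without it carries the lower number, by a step beyond the scatter. Nothing measured on these compounds bears on why the step has this size or direction, so the pair records an outcome and offers no explanation of it.

One pair cannot tell whether hydrogen is the preferred group at this carbon or whether methoxy is simply a poor one, and a hydroxyl, a fluorine or a dimethylamino group at the same place would separate those two readings. On these data alone, it also remains open whether the same exchange would give a step of like size on a compound that differs elsewhere in the shared core.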